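Compound 3 and the substituent change from compound 2

The source may report more compounds than this note shows. Statements on the series, on what has been measured and on what is new or still open speak of the compounds shown alone.

Measured so far:
Compound 1 `CC1(C)CC(NC(=O)c2ccc(Nc3ncc([N+](=O)[O-])c(NC4CCCC4)n3)cc2)CC(C)(C)N1[O]`: 41200 nM
Compound 2 `CCN1CCN(c2nc(Nc3ccc(C(=O)NC4CC(C)(C)N([O])C(C)(C)C4)cc3)ncc2[N+](=O)[O-])CC1`: 39700 nM

Both compounds were tested in a functional assay on LoVo cells (Homo sapiens) for antiproliferative activity, read by MTT assay, with a stated time of 48 h; on this read-out higher numbers stand for weaker inhibition and lower numbers for stronger inhibition. Compound 1 gives 41200 nM and compound 2 gives 39700 nM; the step between them, a 1.0-fold lower number from compound 1 to compound 2 (0.02 log units; within the scatter), shows that the two numbers cannot be told apart, so neither compound stands out from the other on the numbers shown.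

Compound 3 `Cc1cc(Nc2nc(Nc3ccc(C(=O)NC4CC(C)(C)N([O])C(C)(C)C4)cc3)ncc2[N+](=O)[O-])no1` has not been measured. It differs from compound 2 in one place: (5-methyl-1,2-oxazol-3-yl)amino in place of 4-ethylpiperazin-1-yl on an aromatic carbon. Going by the values given here, the only measured step in the set, a 1.0-fold lower number from compound 1 to compound 2 (0.02 log units; within the scatter), changed the group at this same aromatic carbon and left the number essentially unchanged. Among the compounds with values here, that single step is the only guide, and it points to little movement; the new group, however, brings one hydrogen-bond donor and an aromatic five-membered ring that neither measured group has, so the expectation carries a wide range.

Compound 3 is therefore expected to give about 40000 nM in this assay, between 14000 nM and 115000 nM, a step of a 1.0-fold higher number from compound 2 to compound 3 (0.00 log units; within the scatter) that is expected to lie within the scatter.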

Compound 3, half-maximal inhibitory concentration: 26800 nM
Compound 3: the middle estimate sits 1.5-fold (0.17 log units) above what was measured; the range from low to high includes it.
By their numbers in this assay, from the lowest: compounds 3, 2 and 1 (each within the scatter of the next).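

Going by these compounds alone, at the aromatic carbon ortho to a nitro group, this assay now covers a five-membered aromatic ring as well as the two non-aromatic rings of the earlier compounds. With (5-methyl-1,2-oxazol-3-yl)amino in place of 4-ethylpiperazin-1-yl, the step is a 1.5-fold lower number from compound 2 to compound 3 (0.17 log units; within the scatter), and with 5-methyl-1,2-oxazol-3-yl in place of cyclopentyl on the nitrogen, it is a 1.5-fold lower number from compound 1 to compound 3 (0.19 log units; within the scatter). Across these three compounds, then, neither an aromatic ring at this position nor the hydrogen-bond donor that enters in place of 4-ethylpiperazin-1-yl carries the number beyond the scatter, which the step between the two earlier compounds could not show. Nothing measured alongside these numbers helps to interpret this result.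

The compounds shown leave open whether a group of another kind at this carbon, such as a carboxylic acid, a primary amine or a longer alkyl chain, would separate itself from these three. They also leave open whether the number would respond at all to a change elsewhere, for instance a nitrile in place of the nitro group.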